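The compounds below may be only part of what the source reports. "The series", "measured", "known", "first", "only" and "open" are said of these compounds alone.

Three compounds were measured in an assay (Canis lupus familiaris) for binding affinity to platelet-activating factor receptor (Homo sapiens), read by radioligand binding; a lower number here means a stronger inhibitor, a higher number a weaker inhibitor:

Compound 1 `C=CCc1cc(C(=O)N[C@H](C)CCCc2cccnc2)ccc1-c1ccc(OC)c(OC)c1` gives 80 nM.
Compound 2 `CCCCc1cc(C(=O)N[C@H](C)CCCc2cccnc2)ccc1-c1ccc(OC)c(OC)c1` gives 4 nM.
Compound 3 `CCc1cc(C(=O)N[C@H](C)CCCc2cccnc2)ccc1-c1ccc(OC)c(OC)c1` gives 4 nM.

Compound 3 stands level with compound 2, and together they hold the lowest numbers of the three; the step of no change at the digits printed from compound 2 to compound 3 (within the scatter) shows that shortening the chain changed nothing. Compound 1 sits furthest away: the steps of a 20-fold lower number from compound 1 to compound 3 (1.30 log units; beyond the scatter) and a 20-fold lower number from compound 1 to compound 2 (1.30 log units; beyond the scatter) are both large, so the compound carrying vinyl on the saturated chain carbon is clearly the weakest of the set.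

Compound 4 `C#Cc1cc(C(=O)N[C@H](C)CCCc2cccnc2)ccc1-c1ccc(OC)c(OC)c1` has not been measured. It differs from compound 3 in one place: ethynyl in place of ethyl on an aromatic carbon. For the measured compounds named here, the only steps that bear on this change are those from compound 1, where removing an unsaturated group from the side chain lowered the number strongly, as a 20-fold lower number from compound 1 to compound 3 (1.30 log units; beyond the scatter) records. Here an unsaturated group is reintroduced, though now directly on the aromatic carbon rather than on the chain, so no measured step matches the change exactly. Compound 4 is therefore expected to be somewhat weaker than compound 3, with the step of a 3.8-fold higher number from compound 3 to compound 4 (0.57 log units; beyond the scatter) estimated as moderate in this assay. Compound 4 is estimated at 15 nM, within a range from 4 nM to 60 nM.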

Compound 4, half-maximal inhibitory concentration: 5 nM
The estimate for compound 4 lay 3.0-fold (0.48 log units) above the measured number; low and high end bracket the measured number.
By their numbers in this assay, from the lowest: compounds 2, 3 and 4 (each within the scatter of the next); then compound 1.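

In this assay the ethynyl group on the aromatic carbon ortho to a 3,4-dimethoxyphenyl group and meta to a large group matches the saturated chains there, within the scatter on both comparisons (a 1.3-fold higher number from compound 3 to compound 4 (0.10 log units; within the scatter); a 1.3-fold higher number from compound 2 to compound 4 (0.10 log units; within the scatter)). For the compounds shown here, the earlier compounds had linked the one unsaturated group they carried, allyl in compound 1, to a much higher number, but compound 4 shows that a group with a triple bond outside aromatic rings can sit at this position with no such loss, and it still stands well clear of the allyl compound (a 16-fold lower number from compound 1 to compound 4 (1.20 log units; beyond the scatter)). Nothing available here accounts for the difference between allyl and ethynyl at this position.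

The compounds shown leave open how this position responds to a plain hydrogen, a methoxy group, a nitrile or an amine, since every group shown here is built of carbon alone. They also leave open whether propyl, the saturated counterpart of allyl, would fall with compound 2 and compound 3 or nearer to compound 1.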